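The source may report more compounds than this note shows. Statements on the series, on what has been measured and on what is new or still open speak of the compounds shown alone.

Measured compounds in a functional assay on Raji cells (Homo sapiens) for antiproliferative activity; a lower number here means a stronger inhibitor, a higher number a weaker inhibitor:

compound 1, `O=c1[nH]c(=O)n([C@H]2C[C@@H]3O[PH](O)(O)OC[C@H]3O2)cc1Br`: > 1000 ug/mL
compound 2, `O=c1[nH]c(=O)n([C@H]2C[C@@H]3O[PH](O)(O)OC[C@H]3O2)cc1Cl`: > 1000 ug/mL
compound 3, `O=c1[nH]c(=O)n([C@H]2C[C@@H]3O[PH](O)(O)OC[C@H]3O2)cc1I`: > 500 ug/mL

Each of these values is a limit of the assay and not a number. Compound 3 sits at the limit of > 500 ug/mL in this assay, at which 1 of the 3 values shown sits. Compounds 1 and 2 sit at the limit of > 1000 ug/mL in this assay, at which 2 of the 3 values shown sit. The three steps within this set, a step that the two limits leave unreadable from compound 1 to compound 2, a step that the two limits leave unreadable from compound 1 to compound 3 and a step that the two limits leave unreadable from compound 2 to compound 3, are all of unreadable size: the exchange of one halogen for another on the aromatic carbon never brings the read-out into the measurable range, so no ordering of the three halogens can be drawn from these data.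

Compound 4, `O=c1[nH]c(=O)n([C@H]2C[C@@H]3O[PH](O)(O)OC[C@H]3O2)cc1C(F)(F)F`, differs from compound 3 by trifluoromethyl in place of iodo on an aromatic carbon. For the measured compounds named here, the only measured steps that bear on this position are the three halogen exchanges, and each is unreadable because the values sit at the limit of > 1000 ug/mL in this assay, at which 2 of the 3 values shown sit, and (the limit of > 500 ug/mL in this assay, at which 1 of the 3 values shown sits). The step that the limit leaves unreadable from compound 3 to compound 4 is my own estimate, made with no direction or size readable from the measured steps, and compound 4 is therefore expected to remain in the same region as the measured compounds, most likely again at a limit. The estimate for compound 4 in this assay is 1000 ug/mL, expected to lie between 300 ug/mL and 3000 ug/mL.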

Compound 4, concentration for 50% inhibition: >= 500 ug/mL
Compound 4: a limit, no number; the forecaster's own chance of this, stated with the estimate: 85%; the middle value does not contradict the limit.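

In this assay compound 4 gives >= 500 ug/mL, which is a limit and not a number. For the compounds shown here, compounds 1, 2 and 3 also stand at limits, and no step from any of them to compound 4 can be read. The compounds shown leave open how the three halogens and trifluoromethyl rank, and whether any of them gives a measurable read-out.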